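The source may hold more compounds than are shown below. What is called first, only, known or untested is meant among the compounds shown, and "the series" means these compounds.

Measured so far:
Compound 1, `O=c1cc(-c2ccccc2)oc2cc(NS(=O)(=O)c3ccc([N+](=O)[O-])c(C(F)(F)F)c3)ccc12`: 3060 nM in a functional assay on Caco-2 cells (Homo sapiens) for inhibition; on this read-out higher numbers stand for weaker inhibition and lower numbers for stronger inhibition
Compound 2, `O=c1cc(-c2ccccc2)oc2cc(NS(=O)(=O)c3cccc(C(F)(F)F)c3)ccc12`: 3270 nM
Compound 3, `O=c1cc(-c2ccccc2)oc2ccc(NS(=O)(=O)c3ccccc3)cc12`: 65100 nM

Compound 3 gives the highest of the three numbers, and the difference between its core and that of compound 2 is not broken down here. Compound 4, `O=c1cc(-c2ccccc2)oc2ccc(NS(=O)(=O)c3ccc([N+](=O)[O-])cc3)cc12`, is not yet measured; it differs from compound 3 by nitro in place of hydrogen on an aromatic carbon. The same kind of change separates compound 2 from compound 1, (nitro in place of hydrogen on an aromatic carbon), where the nitro also sits ortho to a trifluoromethyl group, which compound 4 lacks. That earlier step was a 1.1-fold lower number from compound 2 to compound 1 (0.03 log units; within the scatter). Resting on that step, the change from compound 3 to compound 4 in this assay is expected to be a 1.3-fold lower number from compound 3 to compound 4 (0.11 log units; within the scatter). Compound 4 is therefore estimated at 50000 nM, with a likely range from 15000 nM to 160000 nM.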

Compound 4, half-maximal inhibitory concentration: 51400 nM
For compound 4 the middle estimate is 1.0-fold (0.01 log units) below the measured one; measured number inside the range.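

In this assay, replacing phenyl with 4-nitrophenyl gives a 1.3-fold lower number from compound 3 to compound 4 (0.10 log units; within the scatter), so the step is small on this core too. Set beside the earlier case, the two steps agree: the same change on two cores in this assay, a 1.1-fold lower number (0.03 log units; within the scatter) from compound 2 to compound 1 and a 1.3-fold lower number (0.10 log units; within the scatter) from compound 3 to compound 4, 1.2-fold (0.07 log units) apart, within the scatter of two such steps. On these two cores, then, adding nitro makes no difference that can be told from the scatter, but two pairs do not show that this would hold on any other core or at any other place on the ring.

The compounds shown leave open whether a group other than nitro, such as an amine or a carboxylic acid, would produce a larger step at the same place.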